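Replacing a Fluorophenyl Amine with a Methoxyphenyl Amine

This account rests on a few compounds, and the source may have more. Where it says the series, first, only, none or still open, it means among the compounds named here.

Of the compounds shown here, two have been measured in a functional assay on ECa-109 cells for inhibition, with ECa-109 cell line (Homo sapiens) as the target, read by sulforhodamine B assay; on this read-out higher numbers stand for weaker inhibition and lower numbers for stronger inhibition. Compound 1 `O=C1C(Nc2ccccc2F)=CC(=O)c2c1nc1n2[C@H]2OC[C@@H](O)[C@H]2OC1` gives 2660 nM, and compound 2 `O=C1C=C(Nc2ccccc2F)C(=O)c2c1nc1n2[C@H]2OC[C@@H](O)[C@H]2OC1` gives 2760 nM. Compound 2 has the higher of the two numbers, but its gap to compound 1 lies within the usual scatter, so the two cannot be told apart. Compound 3 `COc1ccc(NC2=CC(=O)c3nc4n(c3C2=O)[C@H]2OC[C@@H](O)[C@H]2OC4)cc1` has not been measured yet. It differs from compound 2 in one place (4-methoxyphenyl in place of 2-fluorophenyl on an amine nitrogen). Among the measured compounds shown here, no measured pair shows this change, so nothing anchors its effect. The step of a 1.1-fold lower number from compound 2 to compound 3 (0.04 log units; within the scatter) is expected to stay within the scatter. Compound 3 is estimated at 2500 nM, with a range from 800 nM to 8000 nM.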

Compound 3, half-maximal inhibitory concentration: > 4000 nM
Compound 3 ended at the assay's limit; the forecaster's own chance of this, stated with the estimate: 10%; middle value at least 1.6-fold (0.20 log units) from the limit.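

Compound 3 ended at a limit of the assay, > 4000 nM, so its reading is a limit and not a number. On the amine nitrogen, 4-methoxyphenyl in place of 2-fluorophenyl gives an at least 1.4-fold higher number from compound 2 to compound 3 (0.16 log units; that floor lies within the scatter) in this assay, so this change brought no stronger inhibition. How much weaker compound 3 really is stays unknown because its reading stops at that limit: the limit of > 4000 nM in this assay, at which 1 of the 3 values shown sits.

This change alters both the substituent on the ring and its place, and the compounds shown cannot separate the two. A 2-methoxyphenyl or a 4-fluorophenyl on the same nitrogen would pull them apart.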